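The compounds below may be only part of what the source reports. "The series", "measured", "known", "first", "only" and "open" are said of these compounds alone.

Compound 1 `COc1ccc(-c2c(-c3cc(OC)c(OC)c(OC)c3)ssc2=S)cc1[N+](=O)[O-]` gives 3550 nM in a functional assay on HT-1080 cells (Homo sapiens) for antiproliferative activity, read by MTT assay, with a stated time of 72 h; a higher number here means a weaker inhibitor, a lower number a stronger inhibitor.
Compound 2 `COc1ccc(-c2c(-c3cc(OC)c(OC)c(OC)c3)ssc2=S)cc1N` gives 3000 nM in this assay.
Compound 3 `COc1ccc(-c2c(-c3cc(OC)c(OC)c(OC)c3)ssc2=O)cc1[N+](=O)[O-]` gives only a limit of the assay in this assay, namely > 100000 nM.

The change that turns compound 1 into compound 2 is amino in place of nitro on an aromatic carbon. That step gave a 1.2-fold lower number from compound 1 to compound 2 (0.07 log units; within the scatter). Compound 3 carries a different core from compound 1, and the difference between the two cores is not broken down here. The result for compound 3 sits at the limit of > 100000 nM in this assay, at which 1 of the 3 values shown sits.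

Compound 4 `COc1ccc(-c2c(-c3cc(OC)c(OC)c(OC)c3)ssc2=O)cc1N` has not yet been measured. It differs from compound 3 by amino in place of nitro on an aromatic carbon. The surroundings of the place are described in the same words as for the step from compound 1 to compound 2, so this is the same change. Resting on the measured step of a 1.2-fold lower number from compound 1 to compound 2 (0.07 log units; within the scatter), which stayed within the scatter, the expected step in this assay is a step that the limit leaves unreadable from compound 3 to compound 4. Compound 4 is therefore expected to give about 150000 nM in this assay, with a likely range from 40000 nM to 600000 nM, and most probably again only a limit of the assay.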

Compound 4, half-maximal inhibitory concentration: > 100000 nM
Compound 4: no number, only a limit (the forecaster's own chance of this, stated with the estimate: 75%); the middle value is on the limit's open side.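

Compound 3 and compound 4 both sit at a limit of this assay and give no number, so the size of the step between them cannot be read: the limit of > 100000 nM in this assay, at which 2 of the 4 values shown sit.

The compounds shown leave open how strong compound 3 and compound 4 really are, and whether amino in place of nitro changes anything on this core.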